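The source may report more compounds than this note shows. Statements on the series, on what has been measured and on what is new or still open speak of the compounds shown alone.

Among the compounds with values here, in a functional assay on P388 cells (Mus musculus) for inhibition (on this read-out lower numbers stand for an effect already at smaller amounts and higher numbers for an effect only at larger amounts of compound), only two compounds have been measured so far. Compound 1 `Nc1nc(Cl)c2ncn(C3CCC(CO)C3)c2n1` gives > 100 ug/mL, which is a limit of the assay and not a number. Within the data shown here, compound 2 `Nc1nc(Cl)c2nnn(C3C=CC(CO)C3)c2n1` gives 1 ug/mL, the only actual number available. The two compounds differ in more than one place, and no single change can be read from them.

Compound 3 `Nc1nc(N)c2nnn(C3C=CC(CO)C3)c2n1` departs from compound 2 at a single site: amino in place of chloro on an aromatic carbon. This puts amino in place of chloro on an aromatic carbon, next to the ring nitrogen. Among the measured compounds shown here, no measured pair shows this exchange, so any prediction lacks a direct precedent. A move towards weaker inhibition, beyond the usual scatter, is expected because compound 2 at 1 ug/mL leaves more room in that direction, though this is a judgement and not a measured trend. The expected change is a 20-fold higher number from compound 2 to compound 3 (1.30 log units; beyond the scatter). For compound 3, the estimated value is 20 ug/mL. The expected range for compound 3 runs from 3 ug/mL to 100 ug/mL.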

Compound 3, concentration for half-maximal effect: > 100 ug/mL
Compound 3: no number, only a limit (the forecaster's own chance of this, stated with the estimate: 35%); at least 5.0-fold (0.69 log units) between middle value and limit.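

Within the data shown here, the first direct exchange shows that this aromatic carbon, next to the ring nitrogen, is highly sensitive to substitution: in this assay, amino in place of chloro gives an at least 100-fold higher number from compound 2 to compound 3 (2.00 log units; beyond the scatter). Among these compounds, compound 3 gives > 100 ug/mL, which is a limit of the assay and not a number, so the earlier compounds' open question of what any single change does now has an answer for this one site, though only as a minimum size. The true size of this step cannot be read, because the value of compound 3 lies at the end of the range that the assay reports: the limit of > 100 ug/mL in this assay, at which 2 of the 3 values shown sit.

What the compounds shown leave open is whether chloro is specifically needed at this aromatic carbon, or whether bromo, methoxy or a methylamino group there would also keep an effect at a measurable concentration. They also leave open how far the value of compound 3 lies past its limit, and whether the same exchange would have a comparable effect on a different core.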